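A few compounds are considered here, and "the series" means these few. Any claim that something is new, unique, unknown or untested is made for them only; others in the source may bear on it.

Measured in a functional assay on NCI/ADR-RES cells (Homo sapiens) for antiproliferative activity; a lower number here means a stronger inhibitor of growth, a higher number a weaker inhibitor of growth:
- compound 1 `CC/C=C\[C@H](C)[C@H](OC(N)=O)[C@@H](C)[C@H](O)[C@@H](C)C/C(C)=C\[C@H](C)[C@@H](O)[C@@H](C)/C=C\[C@@H](O)C[C@H](O)[C@H](C)CO`: 10000 nM
- compound 2 `CC/C=C\[C@H](C)[C@H](OC(N)=O)[C@@H](C)[C@H](O)[C@@H](C)C/C(C)=C\[C@H](C)[C@@H](O)[C@@H](C)/C=C\[C@@H](O)C[C@H](O)[C@H](C)C[C@H](C)C(=O)OC`: 10000 nM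
- compound 3 `CC/C=C\[C@H](C)[C@H](OC(N)=O)[C@@H](C)[C@H](O)[C@@H](C)C/C(C)=C\[C@H](C)[C@@H](O)[C@@H](C)/C=C\[C@@H](O)C[C@@H]1OC(=O)NC[C@H]1C`: 10000 nM

Level with the other two, compound 3 gives 10000 nM. Compound 4 `CC/C=C\[C@H](C)[C@H](OC(N)=O)[C@@H](C)[C@H](O)[C@@H](C)C/C(C)=C\[C@H](C)[C@@H](O)[C@@H](C)/C=C\[C@@H](O)C[C@@H]1OC(=O)[C@H](C)[C@@H](OC)[C@H]1C` keeps the shared core but exchanges the ring-bearing group of compound 3: a group of 11 heavy atoms (8 carbon, 3 oxygen; one six-membered non-aromatic ring with 1 hetero atom) in place of a group of 8 heavy atoms (5 carbon, 1 nitrogen, 2 oxygen; one six-membered non-aromatic ring with 2 hetero atoms), on a saturated chain carbon, two bonds along the chain from a double-bonded chain carbon and an oxygen on a saturated carbon. The nearest evidence is no change at the digits printed from compound 1 to compound 3 (within the scatter) and no change at the digits printed from compound 2 to compound 3 (within the scatter), together with no change at the digits printed from compound 1 to compound 2 (within the scatter). None of these steps goes beyond the scatter, yet none tests a ring with 1 hetero atom, so they set no firm size for this change. A gain in this assay is therefore expected only tentatively, and the uncertainty is wide. The expected step is a 5.0-fold lower number from compound 3 to compound 4 (0.70 log units; beyond the scatter). For compound 4 the estimate is 2000 nM, with an expected range of 150 nM to 10000 nM.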

Compound 4, concentration for 50% growth inhibition: 250 nM
For compound 4 the middle estimate is 8.0-fold (0.90 log units) above the measured one; low and high end bracket the measured number.
By their numbers in this assay, from the lowest: compound 4; then compounds 1, 2 and 3 (each within the scatter of the next).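

In this assay, for the compounds shown here, this position on a saturated chain carbon proves able to shift the read-out, which the earlier compounds did not show: the six-membered ring with 1 hetero atom gives a 40-fold lower number from compound 3 to compound 4 (1.60 log units; beyond the scatter), and the same ring gives a 40-fold lower number from compound 1 to compound 4 (1.60 log units; beyond the scatter). Against the open group of equal size, 11 heavy atoms, there is a 40-fold lower number from compound 2 to compound 4 (1.60 log units; beyond the scatter), so heavy-atom count alone does not set the number here. No measurement available here accounts for this gain. On these data alone, whether an amine or a longer chain on this ring would keep the gain stays open.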